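The compounds below may be only part of what the source reports. "The series", "measured", "known", "first", "only" and "open" are said of these compounds alone.

Of the compounds shown here, two that share one core have been tested in an ADME assay on cells (Rhabdomyosarcoma cell, Homo sapiens) for cytotoxicity, read by MTT assay, with a stated time of 72 h; on this read-out lower numbers stand for higher toxicity in this test and higher numbers for lower toxicity in this test. Compound 1 `Nc1sc2c(c1-c1nc3cc(Cl)ccc3s1)CCC2` gives 59.1 ug/mL. Among the measured compounds shown here, compound 2 `Oc1ccccc1/C=N/c1sc2c(c1-c1nc3ccccc3s1)CCC2` gives 100 ug/mL, the higher of the two numbers, with compound 1 as its only neighbour; the gap between them lies within the scatter of the test, so the two values show no real difference.

Compound 3 `Oc1ccccc1/C=N/c1sc2c(c1-c1nc3cc(Cl)ccc3s1)CCC2` has not yet been measured in this assay. It differs from compound 2 by a single change: chloro in place of hydrogen on an aromatic carbon. Compound 1 carries the same chloro group but differs from compound 2 in a second place as well, so no clean comparison isolates the chloro.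

For compound 3 the step of a 1.4-fold lower number from compound 2 to compound 3 (0.15 log units; within the scatter) is expected to be small, leaning toward a lower number, since compound 1 at 59.1 ug/mL and compound 2 at 100 ug/mL lie within scatter of each other. Compound 3 is therefore expected to give about 70 ug/mL, within a range from 35 ug/mL to 120 ug/mL.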

Compound 3, half-maximal cytotoxic concentration: 269 ug/mL
Beside the measured number, compound 3's estimate is 3.8-fold (0.58 log units) below it, and the stated range ends below it.
By their numbers in this assay, from the lowest: compounds 1 and 2 (each within the scatter of the next); then compound 3.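

In this assay, among the compounds shown here, chloro in place of hydrogen on this aromatic carbon gives a 2.7-fold higher number from compound 2 to compound 3 (0.43 log units; beyond the scatter), the first clean reading of this single change, and it points toward lower toxicity in this test. With the chloro kept, the group of 9 heavy atoms in place of one nitrogen atom gives a 4.6-fold higher number from compound 1 to compound 3 (0.66 log units; beyond the scatter), so each change reads beyond the scatter when the other is present. Compound 1 and compound 2 each carry only one of these two features and lie within the scatter of each other, while compound 3, which carries both, stands clearly apart.

Nothing available here explains why this step arises. Still open, from the compounds shown here alone, are whether bromo or methoxy on the same carbon would give a similar step, and whether chloro has any effect on the shared core without the larger group.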